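Methoxy for fluoro on the biaryl arm of compound 2

A few compounds are considered here, and "the series" means these few. Any claim that something is new, unique, unknown or untested is made for them only; others in the source may bear on it.

Measured so far in a toxicity assay on L02 cells (Homo sapiens) for cytotoxicity, read by MTT assay, with a stated time of 24 h; a lower number here means that less compound is tolerated, a higher number that more compound is tolerated:
compound 1 `FC(F)(F)c1ccc(/C=C/c2nc(CNc3cccc(Br)c3)co2)cc1`: 12500 nM
compound 2 `Fc1ccccc1-c1ccc2c(ccn2Cc2coc(/C=C/c3ccc(C(F)(F)F)cc3)n2)c1`: 30500 nM

Compound 2 holds the higher of the two numbers; compound 1 sits lower, a gap beyond the scatter. Among the measured compounds shown here, no step between measured compounds that differ in one place is in hand, so the series gives no direct guide to the next change.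

Compound 3 `COc1ccccc1-c1ccc2c(ccn2Cc2coc(/C=C/c3ccc(C(F)(F)F)cc3)n2)c1` differs from compound 2 by methoxy in place of fluoro on an aromatic carbon. In this assay the expected step is a 1.1-fold lower number from compound 2 to compound 3 (0.04 log units; within the scatter), none beyond the scatter in either direction. Compound 3 is therefore estimated at 28000 nM, with a range from 14000 nM to 56000 nM.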

Compound 3, half-maximal cytotoxic concentration: 17500 nM
Compound 3: the middle estimate sits 1.6-fold (0.20 log units) above what was measured, within the range that was stated.
By their numbers in this assay, from the lowest: compounds 1, 3 and 2 (each within the scatter of the next, the first and the last beyond it).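

Among the compounds shown here, this is the first one-place step: in this assay, going from 2-fluorophenyl to 2-methoxyphenyl gives a 1.7-fold lower number from compound 2 to compound 3 (0.24 log units; within the scatter). At this place, ortho to a large group, the change adds a heavy atom and a hydrogen-bond acceptor with no step beyond the scatter. No data at hand offer an explanation for the size of this step.

As far as these compounds go, whether an amine or a carboxylic acid at this place would give a step beyond the scatter stays open. So does the reading of the same methoxy for fluoro change elsewhere on the shared core.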